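The compounds below may be only part of what the source reports. "The series", "measured", "known", "first", "only" and "open" are said of these compounds alone.

Of the compounds shown here, three have so far been measured in an assay on HEK293 cells for inhibition of N-acylethanolamine-hydrolyzing acid amidase (Homo sapiens), read by fluorescence, with stated times of 10 min and 50 min; on this read-out lower numbers stand for stronger inhibition and higher numbers for weaker inhibition. Compound 1 `CN1C[C@H](NC(=O)OCCCCC2CCCCC2)C1=O` gives 1980 nM, compound 2 `CON1C[C@H](NC(=O)OCCCCC2CCCCC2)C1=O` gives 16 nM, and compound 3 `CCOCCON1C(=O)[C@@H](NC(=O)OCCCCC2CCCCC2)[C@@H]1C` gives 187 nM, the second highest of the three numbers. For the measured compounds named here, the only single-point step among them, a 120-fold lower number from compound 1 to compound 2 (2.09 log units; beyond the scatter), concerns the group on the ring nitrogen. Compound 4 `COC(=O)c1ccc(ON2C(=O)[C@@H](NC(=O)OCCCCC3CCCCC3)[C@@H]2C)cc1` differs from compound 3 at a different place: 4-(methoxycarbonyl)phenyl in place of 2-ethoxyethyl on an oxygen. Going by the values given here, no measured step touches this oxygen. Among the compounds with values here, the size and direction of the coming change therefore cannot be read from the earlier compounds, and the expectation stays near compound 3 with a wide range. Compound 4 is estimated at 150 nM, between 30 nM and 800 nM, which means an expected step of a 1.2-fold lower number from compound 3 to compound 4 (0.10 log units; within the scatter).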

Compound 4, half-maximal inhibitory concentration: 17 nM
Estimate against measurement, compound 4: 8.8-fold (0.95 log units) above; the whole stated range lies above it.
By their numbers in this assay, from the lowest: compounds 2 and 4 (each within the scatter of the next); then compound 3; then compound 1.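

In this assay there is an 11-fold lower number from compound 3 to compound 4 (1.04 log units; beyond the scatter) on exchanging 2-ethoxyethyl for 4-(methoxycarbonyl)phenyl on this oxygen, so the group placed here can strongly change the number. For the compounds shown here, the oxygen on the amide-type nitrogen in a ring therefore carries a six-membered aromatic ring with no loss of inhibition, which no earlier step could show. Nothing available explains this gain.

Whether the aromatic ring alone or its methoxycarbonyl group accounts for the step stays open. An unsubstituted phenyl or a 4-carboxyphenyl group on the same oxygen would help separate the two.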